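A few compounds are considered here, and "the series" means these few. Any claim that something is new, unique, unknown or untested is made for them only; others in the source may bear on it.

Measured compounds:
Compound 1 `COc1cccc(-c2ccc([C@H]3S[C@@H](C)C(=O)Nc4c3c(C)nn4-c3ccccc3C)cc2)c1`: in an assay on isolated protein for agonist activity at Bile acid receptor (Homo sapiens), read by AlphaScreen, with a stated time of 30 min (on this read-out higher numbers stand for an effect only at larger amounts of compound and lower numbers for an effect already at smaller amounts), compound 1 gives 1800 nM.
Compound 2 `Cc1ccccc1-n1nc(C)c2c1NC(=O)[C@H](C)S[C@@H]2c1ccc(-c2ccsc2)cc1`: in this assay compound 2 gives 1400 nM.
Compound 3 `Cc1ccccc1-n1nc(C)c2c1NC(=O)[C@H](C)S[C@@H]2c1ccc(-c2ccco2)cc1`: in this assay compound 3 gives 3600 nM.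

Among these three numbers, that of compound 3 is the highest. The step of a 2.0-fold higher number from compound 1 to compound 3 (0.30 log units; within the scatter) stays within the scatter, whereas a 2.6-fold higher number from compound 2 to compound 3 (0.41 log units; beyond the scatter) goes beyond it, so compound 3 is set apart from compound 2 but not from compound 1.

Compound 4 `Cc1ccccc1-n1nc(C)c2c1NC(=O)[C@H](C)S[C@@H]2c1ccc(-c2ccccc2)cc1` differs from compound 3 in one place: phenyl in place of furan-2-yl on an aromatic carbon. Both measured steps into compound 3 bear on this change, since each of them also exchanged the ring at this place: a 2.0-fold higher number from compound 1 to compound 3 (0.30 log units; within the scatter) and a 2.6-fold higher number from compound 2 to compound 3 (0.41 log units; beyond the scatter). Compound 1 carries a six-membered carbon-only ring at the same place, as compound 4 does, and compound 1 gives 1800 nM. Compound 4 is therefore expected to land near compound 1, which means a lower number than compound 3. For compound 4 the expected step is a 2.1-fold lower number from compound 3 to compound 4 (0.33 log units; beyond the scatter), modest at most. Compound 4 is estimated at 1700 nM, with a range from 600 nM to 4500 nM.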

Compound 4, half-maximal effective concentration: 990 nM
Beside the measured number, compound 4's estimate is 1.7-fold (0.23 log units) above it; the measured number falls inside the stated range.
By their numbers in this assay, from the lowest: compounds 4, 2, 1 and 3 (each within the scatter of the next, the first and the last beyond it).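

Phenyl in place of furan-2-yl on this aromatic carbon, para to a large group, gives a 3.6-fold lower number from compound 3 to compound 4 (0.56 log units; beyond the scatter) and is the largest step among these compounds in this assay. Phenyl in place of thiophen-3-yl gives a 1.4-fold lower number from compound 2 to compound 4 (0.15 log units; within the scatter) and hydrogen in place of methoxy gives a 1.8-fold lower number from compound 1 to compound 4 (0.26 log units; within the scatter) so compound 4 is not set apart from compound 2 or compound 1. The furan-2-yl ring of compound 3 therefore separates it from compound 2 and compound 4, but not from compound 1, which keeps the pattern from being a clean split between furan-2-yl and the other groups.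

From the compounds shown here alone, whether an amine, a carboxylic acid or a longer chain at this place would move the number in either direction remains open. Nothing available explains why furan-2-yl and phenyl differ here.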